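A few compounds are considered here, and "the series" means these few. Any claim that something is new, unique, unknown or untested is made for them only; others in the source may bear on it.

Measured in a functional assay on the whole organism (strain Kunming) with Mus musculus as the target, with a stated time of 0.5 h; a lower number here means that less compound is needed, a higher number that more compound is needed for the effect:
- compound 1 `COc1cc(OC)c(OC)cc1/C=C/COC(=O)/C=C/c1ccc(OC)c(OC)c1`: 140 umol/kg
- compound 2 `COc1cc(OC)c(OC)cc1/C=C/COC(=O)/C=C/c1ccc(Br)cc1`: 143 umol/kg
- compound 3 `COc1ccc(/C=C/C(=O)OC/C=C/c2cc(OC)c(OC)cc2OC)cc1`: 184 umol/kg

Compound 3, at 184 umol/kg, cannot be separated from the other two measured compounds. The gaps are a 1.3-fold higher number from compound 1 to compound 3 (0.12 log units; within the scatter) and a 1.3-fold higher number from compound 2 to compound 3 (0.11 log units; within the scatter).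

Compound 4 `COc1cc(OC)c(OC)cc1/C=C/COC(=O)/C=C/c1ccc(Cl)cc1` has chloro in place of methoxy on an aromatic carbon, para to a large group, so 4-methoxyphenyl becomes 4-chlorophenyl (chloro in place of methoxy on an aromatic carbon). Among the compounds with values here, no chloro compound has been measured in this set. The closest evidence is the 4-bromophenyl compound 2, with a 1.3-fold higher number from compound 2 to compound 3 (0.11 log units; within the scatter), which exchanges methoxy and bromo at the same place. Removing the methoxy group gives a 1.3-fold higher number from compound 1 to compound 3 (0.12 log units; within the scatter), and replacing the whole aryl group gives a 1.0-fold higher number from compound 1 to compound 2 (0.01 log units; within the scatter). All three measured steps are small, so no step beyond the scatter is expected in this assay. The expected change is a 1.2-fold lower number from compound 3 to compound 4 (0.09 log units; within the scatter). For compound 4 the estimated value is 150 umol/kg, with an expected range of 90 umol/kg to 250 umol/kg.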

Compound 4, dose for half-maximal effect: 137 umol/kg
For compound 4 the middle estimate is 1.1-fold (0.04 log units) above the measured one, within the range that was stated.
By their numbers in this assay, from the lowest: compounds 4, 1, 2 and 3 (each within the scatter of the next).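

In this assay, on an aromatic carbon para to a large group, chloro in place of methoxy gives a 1.3-fold lower number from compound 3 to compound 4 (0.13 log units; within the scatter) and chloro in place of bromo gives a 1.0-fold lower number from compound 2 to compound 4 (0.02 log units; within the scatter), so this place does not separate these three substituents. Exchanging the whole aryl group, with 4-chlorophenyl in place of 3,4-dimethoxyphenyl, gives a 1.0-fold lower number from compound 1 to compound 4 (0.01 log units; within the scatter), which extends the flat picture from bromo to a second halogen. No measurement accompanies these values that could account for them.

As far as these compounds go, whether any group at this place gives a step beyond the scatter stays open, for example an amine or a carboxylic acid. All four compounds also share the rest of the core of compound 1, so the response to changes there cannot be read.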